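A Methoxybenzyl Swap Against an Unbroken Assay Limit

The source may report more compounds than this note shows. Statements on the series, on what has been measured and on what is new or still open speak of the compounds shown alone.

Measured so far in a functional assay on L02 cells (Homo sapiens) for inhibition, read by Griess assay, with stated times of 1 h and 24 h; on this read-out higher numbers stand for weaker inhibition and lower numbers for stronger inhibition:
Compound 1 `C(=C/c1nc(Nc2ccccc2)c2sccc2n1)\c1ccccc1`: > 1000000 nM (a limit)
Compound 2 `Brc1ccc(Nc2nc(/C=C/c3ccccc3)nc3ccsc23)cc1`: > 1000000 nM (a limit)
Compound 3 `Brc1ccc(CNc2nc(/C=C/c3ccccc3)nc3ccsc23)cc1`: > 1000000 nM (a limit)

None of these three entries is a number, and the series offers only (the limit of > 1000000 nM in this assay, at which 3 of the 3 values shown sit). Compound 3 therefore has no exact place in the series, and its entry of > 1000000 nM is a limit.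

Compound 4 `COc1cccc(CNc2nc(/C=C/c3ccccc3)nc3ccsc23)c1` has not yet been measured. It differs from compound 3 by 3-methoxyphenyl in place of 4-bromophenyl on a saturated chain carbon bound to a nitrogen on an aromatic ring.

The closest evidence gives no size. It consists of a step that the two limits leave unreadable from compound 2 to compound 3, a step that the two limits leave unreadable from compound 1 to compound 3 and a step that the two limits leave unreadable from compound 1 to compound 2. No measured change has yet brought a compound off the limit in this assay, so no direction can be argued. The expected result is a number no higher from compound 3 to compound 4 (the limit leaves the size open), with no clear movement anticipated.

For compound 4 the estimate is 1000000 nM, with an expected range from 200000 nM to 3000000 nM.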

Compound 4, half-maximal inhibitory concentration: > 1000000 nM
Compound 4 gave a limit, no number (the forecaster's own chance of this, stated with the estimate: 75%); the middle value sits exactly at the limit.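

In this assay compound 4 gives > 1000000 nM as a limit and not a number. Within the data shown here, no step from compound 1, compound 2 or compound 3 to compound 4 can be read, because all four compounds sit at the same limit: the limit of > 1000000 nM in this assay, at which 4 of the 4 values shown sit. The compounds shown leave open whether any change brings a compound off this limit.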